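Diaryl ether amine series: replacing the bromobenzylamine with dimethylamine

This account rests on a few compounds, and the source may have more. Where it says the series, first, only, none or still open, it means among the compounds named here.

Measured compounds:
compound 1 `COc1cc(Oc2cccc(Nc3ccccc3)c2)cc(OC)c1CNCc1ccc(Br)cc1`: 3060 nM
compound 2 `COc1cc(Oc2cccc(Nc3ccccc3)c2)cc(OC)c1CNCc1ccccc1`: 3340 nM
compound 3 `COc1cc(Oc2cccc(Nc3ccccc3)c2)cc(OC)c1CN[C@H](C)c1ccccc1`: 5120 nM

In a functional assay on HT-29 cells (Homo sapiens) for inhibition, read by MTT assay, with a stated time of 72 h (a higher number here means a weaker inhibitor, a lower number a stronger inhibitor), compound 1 gives the lowest of the three numbers, but its steps to compound 2 a 1.1-fold higher number from compound 1 to compound 2 (0.04 log units; within the scatter) and to compound 3 a 1.7-fold higher number from compound 1 to compound 3 (0.22 log units; within the scatter) are within the scatter, so the three compounds cannot be ranked. Compound 4 `COc1cc(Oc2cccc(Nc3ccccc3)c2)cc(OC)c1CN(C)C` differs from compound 1 by dimethylamino in place of (4-bromobenzyl)amino on a saturated chain carbon bound to an aromatic carbon. The measured steps only vary the benzyl group: the step of a 1.5-fold higher number from compound 2 to compound 3 (0.19 log units; within the scatter) is also within the scatter. Within the data shown here, none removes the aromatic ring, so no step bears directly on this change; a modest loss is expected. In this assay compound 4 is estimated at 5500 nM (range 2200 nM to 14000 nM), an expected step of a 1.8-fold higher number from compound 1 to compound 4 (0.25 log units; within the scatter).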

Compound 4, half-maximal inhibitory concentration: > 20000 nM
Compound 4 ended at the assay's limit; the forecaster's own chance of this, stated with the estimate: 10%; middle value at least 3.6-fold (0.56 log units) from the limit.
By their numbers in this assay, from the lowest: compounds 1, 2 and 3 (each within the scatter of the next). At a limit, above all of these: compound 4.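

In this assay compound 4 gives > 20000 nM, which is a limit of the assay and not a number. All three steps to it lie beyond the scatter: an at least 6.5-fold higher number from compound 1 to compound 4 (0.81 log units; beyond the scatter), an at least 5.9-fold higher number from compound 2 to compound 4 (0.77 log units; beyond the scatter) and an at least 3.9-fold higher number from compound 3 to compound 4 (0.59 log units; beyond the scatter). Changes to the benzyl group among compound 1, compound 2 and compound 3 stayed within the scatter, so this is the first change at this place that clearly shifts the number, and the aromatic ring of the amine substituent leaves with it.

Dimethylamino removes that ring and the hydrogen-bond donor together, and the compounds shown do not separate the two. A benzyl(methyl)amino group or a (cyclohexylmethyl)amino group at this place would bear on that.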